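The source may hold more compounds than are shown below. What is called first, only, known or untested is meant among the compounds shown, and "the series" means these compounds.

Compound 1 `CCC#C[C@@]1(O)[C@@H](CO)O[C@@H](n2ccc(N)nc2=O)[C@@H]1O` is measured in a functional assay on KB cells (Homo sapiens), read by MTT assay (on this read-out higher numbers stand for weaker inhibition and lower numbers for stronger inhibition), where compound 1 gives 108000 nM. Compound 2 `CCC#C[C@@]1(O)[C@@H](CO)O[C@@H](n2ccc(=O)[nH]c2=O)[C@@H]1O` gives 226000 nM in this assay. Compound 1 therefore holds the lower of the two numbers, and the gap between them lies beyond the usual scatter.

Compound 3 `C#CC[C@@]1(O)[C@@H](CO)O[C@@H](n2ccc(N)nc2=O)[C@@H]1O` keeps the core of compound 1 but changes one group on a saturated ring carbon, with propargyl in place of but-1-yn-1-yl (propargyl in place of but-1-yn-1-yl on a saturated ring carbon). Within the data shown here, no measured pair of compounds shows what this change does, so any forecast is uncertain. The best starting point is compound 1 at 108000 nM, and no step beyond the scatter is expected in this assay, in either direction. The estimate amounts to a step of a 1.1-fold lower number from compound 1 to compound 3 (0.03 log units; within the scatter), which is expected to remain small. Compound 3 is estimated at 100000 nM, with an expected range of 30000 nM to 300000 nM.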

Compound 3, half-maximal inhibitory concentration: > 350000 nM
Compound 3 gave a limit, no number; the forecaster's own chance of this, stated with the estimate: 25%; middle value at least 3.5-fold (0.54 log units) from the limit.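

In this assay compound 3 reads > 350000 nM, which is a limit of the assay and not a number. Even so, replacing but-1-yn-1-yl with propargyl on this saturated ring carbon gives an at least 3.2-fold higher number from compound 1 to compound 3 (0.51 log units; beyond the scatter), so inhibition weakens and this position proves sensitive to a small change in its side chain, something the earlier compounds could not show because they share this chain. Both chains hold one triple bond, so its presence alone does not preserve the value, and the size of the step is bounded from one side only: the limit of > 350000 nM in this assay, at which 1 of the 3 values shown sits.

The compounds shown leave open how a longer alkyne chain, a plain ethyl group or an amine at this carbon would read. They also leave open whether the same swap would weaken inhibition on compound 2.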